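The source may report more compounds than this note shows. Statements on the series, on what has been measured and on what is new or still open speak of the compounds shown alone.

Measured compounds in an assay on CHO-K1 cells for antagonist activity at transient receptor potential cation channel subfamily V member 1 (Homo sapiens), read by FLIPR and calcium flux, with a stated time of 6 min; on this read-out higher numbers stand for weaker inhibition and lower numbers for stronger inhibition:
- compound 1 `O=C(NCc1cc(C(F)(F)F)nn1-c1cccc(Cl)c1)Nc1cccc2[nH]ncc12`: 0.9 nM
- compound 2 `O=C(NCc1cc(C(F)(F)F)nn1-c1ccc(C(F)(F)F)cc1)Nc1cccc2[nH]ncc12`: 3.8 nM
- compound 3 `CC(C)c1ccc(-n2nc(C(F)(F)F)cc2CNC(=O)Nc2cccc3[nH]ncc23)cc1`: 4.1 nM

Compound 2 holds the second highest of the three numbers. Its nearest neighbour is compound 3, with a 1.1-fold higher number from compound 2 to compound 3 (0.03 log units; within the scatter), which is within the scatter. Compound 1 is the lowest number, and the step of a 4.2-fold higher number from compound 1 to compound 2 (0.63 log units; beyond the scatter) lies beyond the scatter, as does a 4.6-fold higher number from compound 1 to compound 3 (0.66 log units; beyond the scatter); both of those steps change the group on the aromatic nitrogen.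

Compound 4 `CC(C)(C)c1cc(CNC(=O)Nc2cccc3[nH]ncc23)n(-c2ccc(C(F)(F)F)cc2)n1` has not yet been measured. It differs from compound 2 in one place: tert-butyl in place of trifluoromethyl on an aromatic carbon. Among the compounds with values here, the only measured step that bears on this place is the one from compound 2 to compound 3, where isopropyl replaces trifluoromethyl on the same aromatic carbon and the number moves only within the scatter. The steps from compound 1 concern the aromatic nitrogen and say nothing about this position. On that basis, no step beyond the scatter is expected for compound 4 in this assay, in either direction.

Compound 4 is therefore estimated at 4.2 nM, with a range from 1.8 nM to 10 nM. The step this estimate implies, a 1.1-fold higher number from compound 2 to compound 4 (0.04 log units; within the scatter), is expected to stay within the scatter.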

Compound 4, inhibition constant: 19.6 nM
For compound 4 the middle estimate is 4.7-fold (0.67 log units) below the measured one; the whole stated range lies below it.
By their numbers in this assay, from the lowest: compound 1; then compounds 2 and 3 (each within the scatter of the next); then compound 4.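

In this assay, putting tert-butyl in place of trifluoromethyl on this aromatic carbon of the five-membered aromatic ring with 2 nitrogen gives a 5.2-fold higher number from compound 2 to compound 4 (0.71 log units; beyond the scatter) and so shows that the number responds to a change at this position. The earlier compounds shown here could not show this, since compounds 1, 2 and 3 all carry trifluoromethyl on this carbon; the step of a 1.1-fold higher number from compound 2 to compound 3 (0.03 log units; within the scatter) belongs to a different place, the trifluoromethyl of the 4-(trifluoromethyl)phenyl group, which compound 4 keeps unchanged. The data shown contain nothing that accounts for the size of the new step.

With tert-butyl the only replacement shown on this carbon, it remains open how the number would respond to other groups there, such as methyl, cyclopropyl, an amine or a carboxylic acid. As far as these compounds go, it is also open whether the same exchange would give a step of similar size with the 3-chlorophenyl group of compound 1 on the ring nitrogen, or with the 4-isopropylphenyl group of compound 3.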